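Shortening the Amine Arm of a Benzohydroxamate

The compounds below may be only part of what the source reports. "The series", "measured", "known", "first", "only" and "open" are said of these compounds alone.

Measured so far in an assay on Sf9 cells for inhibition of protein deacetylase HDAC6 (Homo sapiens), read by fluorescence; on this read-out higher numbers stand for weaker inhibition and lower numbers for stronger inhibition:
compound 1 `NCc1ccc(C(=O)NO)cc1`: 695 nM
compound 2 `O=C(NO)c1ccc(Cc2nnc[nH]2)cc1`: 198 nM

For the measured compounds named here, compound 1 has the higher of the two numbers; the only measured step, a 3.5-fold lower number from compound 1 to compound 2 (0.55 log units; beyond the scatter), runs toward stronger inhibition. Compound 3 `Nc1ccc(C(=O)NO)cc1` differs from compound 1 by amino in place of aminomethyl on an aromatic carbon. No measured step copies this change: the one step shown puts a larger ring group onto the same saturated chain carbon, whereas here that carbon is removed and the nitrogen sits directly on the aromatic ring. That step bears on the question only loosely, showing that the region accepts change at all. With nothing closer to lean on, compound 3 is expected to land near compound 1, leaning toward weaker inhibition, a step of a 2.2-fold higher number from compound 1 to compound 3 (0.33 log units; beyond the scatter). The estimate for compound 3 is 1500 nM, within 400 nM to 6000 nM.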

Compound 3, half-maximal inhibitory concentration: 1400 nM
Compound 3: the middle estimate sits 1.1-fold (0.03 log units) above what was measured; measured number inside the range.
By their numbers in this assay, from the lowest: compound 2; then compounds 1 and 3 (each within the scatter of the next).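

Replacing aminomethyl with amino on the aromatic carbon para to the hydroxycarbamoyl group gives a 2.0-fold higher number from compound 1 to compound 3 (0.30 log units; within the scatter), so this assay does not separate these two compounds. The earlier step only exchanged the amino group on the saturated chain carbon, whereas this one shows that the chain carbon itself can be removed with no difference beyond the scatter, at least when the group carried is amino. Nothing available explains this result, and no measurement beyond these numbers bears on it.

Open, on these data alone, is whether a longer chain ending in an amine, such as aminoethyl, would also stay within the scatter of compound 1. So is whether a carboxylic acid on the same aromatic carbon would be tolerated in the way amino is.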